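From isobutoxy to benzyloxy: forecast for compound 4

The source may hold more compounds than are shown below. What is called first, only, known or untested is meant among the compounds shown, and "the series" means these compounds.

Compound 2 `CC(C)COc1ccccc1C1CC(=O)c2ccccc2O1` stands lowest of the three measured numbers in a functional assay on RAW264.7 cells (Mus musculus) for inhibition, read by immunoassay, with a stated time of 12 h, tested at 30 uM (a lower number here means less inhibition, a higher number more inhibition at the concentration tested (going by the name of the read-out)), where compound 2 gives 30.4%. Compound 1 `CC(C)CCOc1ccccc1C1CC(=O)c2ccccc2O1` gives 47.6%, and compound 3 `CC(C)=CCOc1ccccc1C1CC(=O)c2ccccc2O1` gives 41.8%. Both steps away from compound 2 run upward and beyond the scatter: a number 11.4 percentage points higher from compound 2 to compound 3 (beyond the scatter), and, read in the opposite direction, a number 17.2 percentage points lower from compound 1 to compound 2 (beyond the scatter). Between compound 1 and compound 3 the difference is small: a number 5.8 percentage points lower from compound 1 to compound 3 (within the scatter).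

Compound 4 `O=C1CC(c2ccccc2OCc2ccccc2)Oc2ccccc21` differs from compound 2 at the same place: phenyl in place of isopropyl on a saturated chain carbon bound to an oxygen on an aromatic ring. Cut one bond further out, isobutoxy becomes benzyloxy. Within the data shown here, the two measured steps from isopropyl to a larger group both bear on this change and both were modest rises; no measured compound carries a phenyl here, so the anchor is loose. A modest rise in this assay is expected, a number 14.6 percentage points higher from compound 2 to compound 4 (beyond the scatter), in the same direction as those two steps. For compound 4 the estimated value in this assay is 45%, within a range of 30% to 62%.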

Compound 4, a percentage reported as inhibition, at one concentration (the size of the read-out at that concentration, not a potency): 93.2%
The estimate for compound 4 lay 48.2 percentage points below the measured number, outside the stated range (above it).
By their numbers in this assay, from the lowest: compound 2; then compounds 3 and 1 (each within the scatter of the next); then compound 4.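

In this assay, phenyl at this place, on a saturated chain carbon bound to an oxygen on an aromatic ring, gives a number 62.8 percentage points higher from compound 2 to compound 4 (beyond the scatter) and a number 51.4 percentage points higher from compound 3 to compound 4 (beyond the scatter) and a number 45.6 percentage points higher from compound 1 to compound 4 (beyond the scatter) in the three comparisons. Each of these steps is large, whereas the steps among the isopropyl, isobutyl and 2-methylprop-1-en-1-yl groups were at most modest, so this position can shift the read-out much further than those three compounds showed. No available evidence bears on why phenyl has this effect.

From the compounds shown here alone, whether the rise needs an aromatic ring stays open, since a cyclohexyl group would separate the ring from its aromatic character. Going by these compounds, how far the effect carries to a pyridine ring, a fluorophenyl group or a longer chain ending in phenyl also remains unknown.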